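Removing a thiazole methyl in a hydroxamic acid HDAC6 inhibitor

The compounds below may be only part of what the source reports. "The series", "measured", "known", "first", "only" and "open" are said of these compounds alone.

Of the compounds shown here, two have been measured in an assay on cells for inhibition of protein deacetylase HDAC6 (Homo sapiens), read by fluorescence, with a stated time of 24 h; on this read-out higher numbers stand for weaker inhibition and lower numbers for stronger inhibition. Compound 1, `CC(NC(=O)c1nc(-c2nccs2)sc1C1CC1)c1ccc(C(=O)NO)cc1`, gives 41.7 nM. Compound 2, `Cc1cnc(-c2nc(C(=O)N[C@@H](C)c3ccc(C(=O)NO)cc3)c(C3CC3)s2)s1`, gives 18.5 nM, the lowest of the two numbers; its nearest neighbour is compound 1, whose number is higher by a gap beyond the scatter. Compound 3, `C[C@H](NC(=O)c1nc(-c2nccs2)sc1C1CC1)c1ccc(C(=O)NO)cc1`, has not yet been measured in this assay. It differs from compound 2 by hydrogen in place of methyl on an aromatic carbon. Among the measured compounds shown here, no step of this exact kind has been measured, so the size of the change is an expectation only. The loss of a single carbon at this site is expected to cost little, and the step from compound 2 to compound 3 is estimated as a 1.6-fold higher number from compound 2 to compound 3 (0.21 log units; within the scatter), a modest move toward weaker inhibition, close to the scatter. Compound 3 is therefore expected to give 30 nM, within 12 nM to 75 nM, a range that also covers compound 1 because it gives 41.7 nM.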

Compound 3, half-maximal inhibitory concentration: 14 nM
Compound 3: the middle estimate sits 2.1-fold (0.33 log units) above what was measured; the measured number falls inside the stated range.
By their numbers in this assay, from the lowest: compounds 3 and 2 (each within the scatter of the next); then compound 1.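

In this assay, removing the methyl from the aromatic carbon next to the ring sulfur, which turns 5-methyl-1,3-thiazol-2-yl into 1,3-thiazol-2-yl, gives a 1.3-fold lower number from compound 2 to compound 3 (0.12 log units; within the scatter), so the methyl can be lost at this position without a change that this read-out can resolve. The separation beyond the scatter appears elsewhere, in a 3.0-fold lower number from compound 1 to compound 3 (0.47 log units; beyond the scatter), and this pair has the same atoms and bonds. The only difference between them is in how the stereocentre at the saturated chain carbon is drawn: the fact that one of compounds 1 and 3 is drawn with a defined configuration and the other without, at the place where they differ

The compounds shown leave open what the opposite configuration at that stereocentre would give. They also leave open whether this aromatic carbon would accept anything other than hydrogen or methyl, such as an ethyl group, a methoxy group or an amine.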